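This account rests on a few compounds, and the source may have more. Where it says the series, first, only, none or still open, it means among the compounds named here.

Compound 1 `Cc1ccc2c(n1)OC[C@H](NC(=O)c1n[nH]c(Cc3ccccc3)n1)C(=O)N2C`: 363 nM
Compound 2 `CN1C(=S)[C@@H](NC(=O)c2n[nH]c(Cc3ccccc3)n2)COc2ccccc21`: 2.8 nM; 7.4 nM (2 entries)
Compound 3 `CN1C(=S)[C@@H](NC(=O)c2n[nH]c(Cc3ccccc3)n2)COc2cccnc21`: 13.7 nM

In a functional assay on HT-29 cells (Homo sapiens) for inhibition, read by luminescence and CellTiter-Glo, with a stated time of 10 h (on this read-out lower numbers stand for an effect already at smaller amounts and higher numbers for an effect only at larger amounts of compound), compound 3 at 13.7 nM lies well below compound 1 at 363 nM, a gap beyond the usual scatter of repeat measurements. Compound 4 `CN1C(=S)[C@H](NC(=O)c2n[nH]c(Cc3ccccc3)n2)COc2cccnc21` is the next structure to consider, and it is closely related to compound 3: the two compounds have the same atoms and bonds and differ only in configuration as drawn: 1 of 1 stereo elements differ; a stereocentre at a saturated ring carbon is drawn S in compound 3 and R in compound 4. For the measured compounds named here, no measured pair here shows what such a switch does, so the expectation rests on the structural change alone. A large move towards higher numbers is expected, an estimated 150-fold higher number from compound 3 to compound 4 (2.16 log units; beyond the scatter), which would lie beyond the scatter. For compound 4 the estimated value is 2000 nM, with an expected range of 200 nM to 10000 nM.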

Compound 4, half-maximal effective concentration: 18.6 nM
Compound 4: middle estimate off by 110-fold (2.03 log units), on the high side; the measured number lies below the stated range.
By their numbers in this assay, from the lowest: compounds 3 and 4 (each within the scatter of the next); then compound 1.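

Switching the stereocentre at a saturated ring carbon from S to R, the first such pair here, gives in this assay a 1.4-fold higher number from compound 3 to compound 4 (0.13 log units; within the scatter). On this read-out, then, the drawn configuration at this carbon has no effect that can be told apart from the usual scatter. Repeat entries of a single compound spread at least as widely as this step: the several entries of compound 2 in this assay, 2.8 nM; 7.4 nM (2 entries)

The compounds shown leave open whether the configuration would matter as little with another group, such as an amine or a carboxylic acid, on the shared core. They also give no explanation for the absence of a clear effect.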